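The compounds below may be only part of what the source reports. "The series", "measured", "known", "first", "only" and "open" are said of these compounds alone.

Working notes on the series.

Compound 1 `CCC/C=C/C(=O)Nc1cccc(Oc2nc(Nc3ccc(OC)cc3)nc3c2CSCC3)c1` gives, in a functional assay on A549 cells (Homo sapiens) for antiproliferative activity, read by MTT assay, with a stated time of 72 h (on this read-out lower numbers stand for stronger inhibition and higher numbers for weaker inhibition), 11900 nM. Compound 2 `COc1ccc(Nc2nc3c(c(Oc4cccc(NC(=O)C=C(C)C)c4)n2)CSCC3)cc1` gives in this assay 26900 nM. Compound 3 `CCC/C=C/C(=O)Nc1cccc(Oc2nc(Nc3ccc(OC)nc3)nc3c2CSCC3)c1` gives in this assay 10800 nM. Compound 4 `COc1ccc(Nc2nc3c(c(Oc4cccc(NC(=O)C=C(C)C)c4)n2)CSCC3)cn1` has not yet been measured in this assay.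

Compound 1 and compound 3 differ in their cores by 6-methoxypyridin-3-yl in place of 4-methoxyphenyl on a nitrogen on an aromatic ring; the two values sit close together, a 1.1-fold lower number from compound 1 to compound 3 (0.04 log units; within the scatter), so nothing of order is read from that pair. Compound 1 and compound 2 differ by 2-methylprop-1-en-1-yl in place of pent-1-en-1-yl on a carbonyl carbon, and the step is a 2.3-fold higher number from compound 1 to compound 2 (0.35 log units; beyond the scatter). Compound 3 and compound 4 differ by 2-methylprop-1-en-1-yl in place of pent-1-en-1-yl on a carbonyl carbon; the two place lines agree word for word, so this is the same change as the one from compound 1 to compound 2, occurring twice in all among the compounds shown, once measured and once not.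

Among the compounds with values here, the expectation for compound 4 rests on the one measured instance of this change, because a 2.3-fold higher number from compound 1 to compound 2 (0.35 log units; beyond the scatter) is the only calibration available, and it is a single pair, so the estimate is held loosely. The step from compound 3 to compound 4 in this assay is expected to be a 2.3-fold higher number from compound 3 to compound 4 (0.36 log units; beyond the scatter), close in size to the measured one. Compound 4 is accordingly estimated at 25000 nM in this assay, with a range from 12000 nM to 52000 nM.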

Compound 4, half-maximal inhibitory concentration: 16800 nM
The estimate for compound 4 lay 1.5-fold (0.17 log units) above the measured number, within the range that was stated.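

In this assay, 2-methylprop-1-en-1-yl in place of pent-1-en-1-yl on the carbonyl carbon now reads on a second core as a 1.6-fold higher number from compound 3 to compound 4 (0.19 log units; within the scatter), and the two instances of this change do not differ beyond what repeated measurement allows: the same change on two cores in this assay, a 2.3-fold higher number (0.35 log units; beyond the scatter) from compound 1 to compound 2 and a 1.6-fold higher number (0.19 log units; within the scatter) from compound 3 to compound 4, 1.5-fold (0.16 log units) apart, within the scatter of two such steps. The aryl change on the nitrogen, 6-methoxypyridin-3-yl in place of 4-methoxyphenyl, reads on the core bearing 2-methylprop-1-en-1-yl as a 1.6-fold lower number from compound 2 to compound 4 (0.20 log units; within the scatter), and it also agrees with its earlier instance: the same change on two cores in this assay, a 1.1-fold lower number (0.04 log units; within the scatter) from compound 1 to compound 3 and a 1.6-fold lower number (0.20 log units; within the scatter) from compound 2 to compound 4, 1.5-fold (0.16 log units) apart, within the scatter of two such steps. Within the data shown here, both changes therefore carry between these cores without a detectable core dependence, but each rests on only two pairs in a single cell assay, and only one of the four steps lies beyond the scatter, so this does not show that either step has a fixed size or that it would hold on a further core.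

The compounds shown leave open how a saturated pentyl chain, a longer chain or a chain carrying an amine would read on the carbonyl carbon in this assay. They also leave open whether an aryl group with a trifluoromethoxy group in place of the methoxy group would follow the same pattern on the nitrogen.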